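The source may hold more compounds than are shown below. What is called first, only, known or untested is meant among the compounds shown, and "the series" means these compounds.

Compound 1 `CC(C)(C)Oc1ccc(-c2nnc(SCCCN3CCN(c4nc5ccccc5o4)CC3)o2)cc1` and compound 2 `Oc1ccc(-c2nnc(SCCCN3CCN(c4nc5ccccc5o4)CC3)o2)cc1` share one core and differ in a single place: hydrogen in place of tert-butyl on an oxygen on an aromatic ring. In a functional assay on HeLa cells (Homo sapiens) for inhibition, read by MTT assay, with a stated time of 72 h (a higher number here means a weaker inhibitor, a lower number a stronger inhibitor), compound 1 gives 269000 nM, while compound 2 gives 99500 nM, so the step is a 2.7-fold lower number from compound 1 to compound 2 (0.43 log units; beyond the scatter). Compound 3 `CC(C)(C)Oc1ccc(-c2nnc(SCCCN3CCN(c4nc5ccccc5s4)CC3)o2)cc1` is built on a second core; how the two cores differ is this: 1,3-benzothiazol-2-yl in place of 1,3-benzoxazol-2-yl on an amine nitrogen in a ring. In this assay compound 3 gives 217000 nM, and the step is a 1.2-fold lower number from compound 1 to compound 3 (0.09 log units; within the scatter), a gap that lies within the scatter. Compound 4 `Oc1ccc(-c2nnc(SCCCN3CCN(c4nc5ccccc5s4)CC3)o2)cc1` has not yet been measured. It differs from compound 3 exactly as compound 2 differs from compound 1: hydrogen in place of tert-butyl on an oxygen on an aromatic ring. The surroundings of the place are the same in both pairs, so this is the same change carried over to the second core. The step expected is a 2.7-fold lower number from compound 3 to compound 4 (0.43 log units; beyond the scatter), because the same change gave a 2.7-fold lower number from compound 1 to compound 2 (0.43 log units; beyond the scatter). Compound 4 is estimated to give 80000 nM in this assay, with a likely range from 40000 nM to 160000 nM.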

Compound 4, half-maximal inhibitory concentration: 139000 nM
Compound 4: the middle estimate sits 1.7-fold (0.24 log units) below what was measured; the range from low to high includes it.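

In this assay, exchanging tert-butoxy for hydroxy on the second core gives a 1.6-fold lower number from compound 3 to compound 4 (0.19 log units; within the scatter), and this step can be set beside the one seen on the first core: the same change on two cores in this assay, a 2.7-fold lower number (0.43 log units; beyond the scatter) from compound 1 to compound 2 and a 1.6-fold lower number (0.19 log units; within the scatter) from compound 3 to compound 4, 1.7-fold (0.24 log units) apart, within the scatter of two such steps. The exchange of the two ring systems on the amine nitrogen, read on the compounds that carry the hydroxy group, gives a 1.4-fold higher number from compound 2 to compound 4 (0.15 log units; within the scatter), and it also agrees with its earlier counterpart: the same change on two cores in this assay, a 1.2-fold lower number (0.09 log units; within the scatter) from compound 1 to compound 3 and a 1.4-fold higher number (0.15 log units; within the scatter) from compound 2 to compound 4, 1.7-fold (0.24 log units) apart, within the scatter of two such steps. So the change carried over from one core to the other without any measurable disagreement, but this rests on just two cores, and the step on the second core is within the scatter by itself, so it does not show a real gain there or that the change would carry over to any further core.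

On these data alone, it remains open how other groups on that oxygen, such as methyl or a longer chain, would behave in this assay. As far as these compounds go, it is equally open whether an amine or a carboxylic acid in place of the hydroxy group would fit the same picture on either core.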